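A few compounds are considered here, and "the series" means these few. Any claim that something is new, unique, unknown or untested is made for them only; others in the source may bear on it.

Measured in a physicochemical assay for solubility, with a stated time of 24 h, tested at 30 mg/mL; a lower number here means a less soluble compound, a higher number a more soluble compound:
- compound 1 `O=C(CCCCCNc1c(Nc2ccc(C(F)(F)F)cc2)c(=O)c1=O)NO`: 4700000 nM
- compound 2 `Cc1ccc(Nc2c(NC(C)CCCCC(=O)NO)c(=O)c2=O)cc1`: 4900000 nM
- compound 3 `COc1ccc(Nc2c(NC(C)CCCCC(=O)NO)c(=O)c2=O)cc1`: 11000000 nM

Compound 3 has the highest number of the three, and its gaps to compound 1 and compound 2 both lie beyond the scatter. Compound 4 `CC(CCCCC(=O)NO)Nc1c(Nc2ccc(C(F)(F)F)cc2)c(=O)c1=O` carries trifluoromethyl in place of methoxy on an aromatic carbon. Among the measured compounds shown here, the only measured step at this place is a 2.2-fold higher number from compound 2 to compound 3 (0.35 log units; beyond the scatter), which is modest and involves a different pair of groups. Compound 1 also carries trifluoromethyl, on a different chain, and gives 4700000 nM. A modest fall is therefore expected, estimated as a 2.3-fold lower number from compound 3 to compound 4 (0.36 log units; beyond the scatter). For compound 4 the estimate is 4800000 nM, with an expected range of 2300000 nM to 9500000 nM.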

Compound 4, solubility: 20000000 nM
Beside the measured number, compound 4's estimate is 4.2-fold (0.62 log units) below it; the measured number lies above the stated range.
By their numbers in this assay, from the lowest: compounds 1 and 2 (each within the scatter of the next); then compounds 3 and 4 (each within the scatter of the next).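

In this assay the step for trifluoromethyl in place of methoxy on an aromatic carbon is a 1.8-fold higher number from compound 3 to compound 4 (0.26 log units; within the scatter) and so does not separate these two groups, whereas a 4.1-fold higher number from compound 2 to compound 4 (0.61 log units; beyond the scatter) comes with trifluoromethyl in place of methyl on the same carbon. With trifluoromethyl held, a 4.3-fold higher number from compound 1 to compound 4 (0.63 log units; beyond the scatter) comes with methyl in place of hydrogen on a saturated chain carbon bound to a nitrogen on an aromatic ring and a saturated chain carbon. No measurement here bears on what lies behind these steps. Open: how an amine or a carboxylic acid on this aromatic carbon would read against compound 3 and compound 4, and whether the chain methyl gives a step of similar size with methoxy or methyl on the ring.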